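The source may report more compounds than this note shows. Statements on the series, on what has been measured and on what is new or still open speak of the compounds shown alone.

Measured in a functional assay on HOS cells (Homo sapiens) for antiproliferative activity, with a stated time of 72 h; on this read-out higher numbers stand for weaker inhibition and lower numbers for stronger inhibition
Compound 1 `OC[C@H]1O[C@@H](n2cnc3c(NCc4ccc(Cl)cc4)ncnc32)[C@H](O)[C@@H]1O` gives > 166000 nM
Compound 2 `OC[C@H]1O[C@@H](n2cnc3c(NCc4cccc(O)c4O)ncnc32)[C@H](O)[C@@H]1O` gives > 166000 nM
Compound 3 `Cc1ccc(O)c(CNc2ncnc3c2ncn3[C@@H]2O[C@H](CO)[C@@H](O)[C@H]2O)c1` gives > 166000 nM

Compound 3 gives > 166000 nM as a limit of the assay and not as a number. The whole set so far reads (the limit of > 166000 nM in this assay, at which 3 of the 3 values shown sit), so nothing ranks these compounds against one another.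

Compound 4 `OC[C@H]1O[C@@H](n2cnc3c(NCc4ccccc4OC(F)F)ncnc32)[C@H](O)[C@@H]1O` differs from compound 3 in one place: 2-(difluoromethoxy)phenyl in place of 2-hydroxy-5-methylphenyl on a saturated chain carbon bound to a nitrogen on an aromatic ring. Here 2-(difluoromethoxy)phenyl stands in place of 2-hydroxy-5-methylphenyl, on a saturated chain carbon bound to a nitrogen on an aromatic ring.

Three measured steps exchange the group at this same place: a step that the two limits leave unreadable from compound 1 to compound 2, a step that the two limits leave unreadable from compound 1 to compound 3 and a step that the two limits leave unreadable from compound 2 to compound 3. None of them offers a size or a direction to carry over, and every exchange so far has ended at the limit.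

The expectation therefore rests on a step that the two limits leave unreadable from compound 1 to compound 3 and the other two steps, and it is that nothing changes visibly. The expected a number no higher from compound 3 to compound 4 (the limit leaves the size open) is no step beyond the scatter, in neither direction. For compound 4 the estimate is 166000 nM, with an expected range from 50000 nM to 250000 nM.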

Compound 4, half-maximal inhibitory concentration: > 166000 nM
Compound 4: only a limit was reported; the forecaster's own chance of this, stated with the estimate: 80%; the middle value sits exactly at the limit.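

Compound 4 also ends at a limit of the assay and not a number, as compound 1, compound 2 and compound 3 do, so none of the steps among them can be read: the limit of > 166000 nM in this assay, at which 4 of the 4 values shown sit.

The compounds shown leave open whether any group at this place would give a readable value.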